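Swapping the halogen on a semicarbazide-linked aniline

The compounds below may be only part of what the source reports. "The series", "measured", "known", "first", "only" and "open" are said of these compounds alone.

Measured so far:
compound 1 `COc1cc(NC(C)CCCNC(=O)Nc2cccc(F)c2)c2ncccc2c1`: 24000 nM
compound 2 `COc1cc(NC(C)CCCNC(=O)NNC(=O)Nc2ccc(F)cc2)c2ncccc2c1`: > 100000 nM
compound 3 `COc1cc(NC(C)CCCNC(=O)NNC(=O)Nc2ccc(Br)cc2)c2ncccc2c1`: 27000 nM

In a functional assay on NCI-H460 cells (Homo sapiens) for inhibition, read by MTT assay, with a stated time of 72 h (a lower number here means a stronger inhibitor, a higher number a weaker inhibitor), compound 1 gives 24000 nM. For compound 2 only a limit of the assay is known, > 100000 nM, so it gives no number. Compound 3, in turn, gives 27000 nM, and the step of an at least 3.7-fold lower number from compound 2 to compound 3 (0.56 log units; beyond the scatter) shows that bromo in place of fluoro moves the number back down into the range of compound 1, as a 1.1-fold higher number from compound 1 to compound 3 (0.05 log units; within the scatter) confirms.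

Compound 4 `COc1cc(NC(C)CCCNC(=O)NNC(=O)Nc2cccc(Cl)c2)c2ncccc2c1` differs from compound 2 by 3-chlorophenyl in place of 4-fluorophenyl on an amide-type nitrogen. Going by the values given here, the only measured guide is an at least 3.7-fold lower number from compound 2 to compound 3 (0.56 log units; beyond the scatter), where a heavier halogen brought a lower number. By that analogy the step of an at least 2.2-fold lower number from compound 2 to compound 4 (0.34 log units; beyond the scatter) is expected to be downward, and compound 4 is estimated at 45000 nM, between 15000 nM and 130000 nM.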

Compound 4, half-maximal inhibitory concentration: 32000 nM
Compound 4: middle estimate off by 1.4-fold (0.15 log units), on the high side; the range from low to high includes it.
By their numbers in this assay, from the lowest: compounds 1, 3 and 4 (each within the scatter of the next). At a limit, above all of these: compound 2.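

Replacing 4-fluorophenyl with 3-chlorophenyl also lowers the number, an at least 3.1-fold lower number from compound 2 to compound 4 (0.49 log units; beyond the scatter), so among these semicarbazides the bromo result is not a lone case. The chloro compound shows no real difference from its neighbours, with a 1.2-fold higher number from compound 3 to compound 4 (0.07 log units; within the scatter) and a 1.3-fold higher number from compound 1 to compound 4 (0.12 log units; within the scatter), which leaves compound 2 as the exception: the limit of > 100000 nM in this assay, at which 1 of the 4 values shown sits.

Going by these compounds, it remains open whether the fluoro atom itself or its place in 4-fluorophenyl sets compound 2 apart, which 4-chlorophenyl or 3-fluorophenyl on the same linker could separate. Also open, on these data alone, is how a ring carrying a nitrile instead of a halogen would behave.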